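A Ring Swap and Its Expected Effect on Inhibition

A few compounds are considered here, and "the series" means these few. Any claim that something is new, unique, unknown or untested is made for them only; others in the source may bear on it.

Measured compounds:
compound 1 `CCCCCCCCN(C)C(=O)Cn1cc(Cc2cnc(OCC)nc2)c(=O)nc1SCc1ccc(F)cc1` — 23%
compound 2 `CCCCCCCCN(C)C(=O)Cn1cc(Cc2cnc(OCc3ccccc3)nc2)c(=O)nc1SCc1ccc(F)cc1` — 10%

In a functional assay on a cell-free system (plasma) for inhibition of platelet-activating factor acetylhydrolase (Homo sapiens), tested at 100 nM (on this read-out lower numbers stand for less inhibition and higher numbers for more inhibition at the one concentration tested (going by the name of the read-out)), compound 1 gives 23%, the higher of the two numbers; compound 2 lies a number 13 percentage points lower from compound 1 to compound 2 (beyond the scatter). Compound 3 `CCCCCCCCN(C)C(=O)Cn1cc(Cc2cnc(=O)n(C)c2)c(=O)nc1SCc1ccc(F)cc1` differs from compound 1 by a group of 8 heavy atoms (5 carbon, 2 nitrogen, 1 oxygen; one six-membered aromatic ring with 2 hetero atoms) in place of a group of 9 heavy atoms (6 carbon, 2 nitrogen, 1 oxygen; one six-membered aromatic ring with 2 hetero atoms), on a saturated chain carbon bound to an aromatic carbon. Among the measured compounds shown here, the only measured step changes a different part of that same arm, and a larger group there lowered inhibition. For the measured compounds named here, no step matches this swap directly, so only a small move, within the scatter, is expected, estimated as a number 5 percentage points lower from compound 1 to compound 3 (within the scatter). Compound 3 is thus expected to reach about 18%, within 4% to 34%.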

Compound 3, a percentage reported as inhibition, at one concentration (the size of the read-out at that concentration, not a potency): 55%
Compound 3: middle estimate off by 37 percentage points, on the low side, outside the stated range (above it).
By their numbers in this assay, from the lowest: compound 2; then compound 1; then compound 3.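

Among the compounds shown here, replacing the 2-ethoxypyrimidin-5-yl group on this saturated chain carbon with the ring of compound 3 gives a number 32 percentage points higher from compound 1 to compound 3 (beyond the scatter), so a change in this arm can raise inhibition, whereas the only earlier step lowered it. The two groups have the same counts of hydrogen-bond donors and acceptors, so those counts do not separate them. Nothing measured here accounts for the gain.

The compounds shown leave open which feature of the entering ring carries this gain, and whether an amine or a carboxylic acid at the same place would keep it.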